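This account rests on a few compounds, and the source may have more. Where it says the series, first, only, none or still open, it means among the compounds named here.

Measured compounds:
compound 1 `N#Cc1c(-c2ccccc2)cn(-c2ccc(S(=O)(=O)Nc3ccccn3)cc2)c1N`: 5300 nM
compound 2 `Nc1nc(=O)[nH]c2c1c(-c1ccccc1)cn2-c1ccc(S(=O)(=O)Nc2nccs2)cc1`: 3490 nM

Of the compounds shown here, two have been tested in a functional assay on HepG2 cells (Homo sapiens) for inhibition, read by sulforhodamine B assay, with a stated time of 24 h; a higher number here means a weaker inhibitor, a lower number a stronger inhibitor. Compound 1 gives 5300 nM and compound 2 gives 3490 nM in this assay; the gap between these two numbers lies within the usual scatter of repeated measurements, so neither compound can be called the stronger or weaker inhibitor on this evidence. Compound 3 `Nc1nc(=O)[nH]c2c1c(-c1ccccc1)cn2-c1ccc(S(=O)(=O)Nc2ccccn2)cc1` has not yet been measured. It differs from compound 2 in one place only: pyridin-2-yl in place of 1,3-thiazol-2-yl on a sulfonamide nitrogen. Among the measured compounds shown here, no pair of measured compounds shows this exact change on the shared core, so its effect cannot be read from the data. The expectation is therefore a step of a 1.1-fold higher number from compound 2 to compound 3 (0.06 log units; within the scatter), which means no shift beyond the scatter in either direction. Compound 3 is estimated to give 4000 nM in this assay, within a range from 1500 nM to 11000 nM.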

Compound 3, half-maximal inhibitory concentration: 4300 nM
Compound 3: middle estimate off by 1.1-fold (0.03 log units), on the low side, within the range that was stated.
By their numbers in this assay, from the lowest: compounds 2, 3 and 1 (each within the scatter of the next).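

On the sulfonamide nitrogen of the shared core, pyridin-2-yl in place of 1,3-thiazol-2-yl gives a 1.2-fold higher number from compound 2 to compound 3 (0.09 log units; within the scatter) in this assay. Compounds 1 and 2 differ in more than one place, so this pair is what isolates the change. On this core, a six-membered aromatic ring with one hetero atom and a five-membered aromatic ring with two hetero atoms on that nitrogen cannot be told apart in this assay, and no other measurement here offers an explanation for the result.

Still open, going by these compounds, is whether a different group on that nitrogen, such as a plain phenyl ring, a methyl group or a bare hydrogen, would also read within the scatter. On these data alone, it is also open whether the same swap would read alike on the core of compound 1, which carries a nitrile.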